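The source may hold more compounds than are shown below. What is called first, only, known or untested is meant among the compounds shown, and "the series" means these compounds.

Measured compounds:
compound 1, `Cc1ccc2oc(/C=C/[S+](C)[O-])cc(=O)c2c1`: 1700 nM
compound 2, `C[S+]([O-])/C=C/c1cc(=O)c2cc(O)ccc2o1`: 10500 nM

In a functional assay on A549 cells (Homo sapiens) for cytotoxicity, with a stated time of 48 h (on this read-out higher numbers stand for weaker inhibition and lower numbers for stronger inhibition), compound 2 gives the highest of the two numbers, with compound 1 the nearest. For the measured compounds named here, the step of a 6.2-fold higher number from compound 1 to compound 2 (0.79 log units; beyond the scatter) is the only measured change, and it does not reproduce the change to compound 3, `CC(C)CCOc1ccc2oc(/C=C/[S+](C)[O-])cc(=O)c2c1`, which is isopentyl in place of hydrogen on an oxygen on an aromatic ring. Going by the values given here, the one step says only that the hydroxy analogue sits at the weaker end. Among the compounds with values here, a capped oxygen bearing an isopentyl chain has no measured counterpart, so the expectation for compound 3 leans on compound 1 and compound 2 together. The estimated step of a 3.0-fold lower number from compound 2 to compound 3 (0.48 log units; beyond the scatter) is toward a lower number. Compound 3 is therefore expected at 3500 nM, range 1000 nM to 12000 nM.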

Compound 3, half-maximal inhibitory concentration: 1000 nM
Estimate against measurement, compound 3: 3.5-fold (0.54 log units) above; low and high end bracket the measured number.
By their numbers in this assay, from the lowest: compounds 3 and 1 (each within the scatter of the next); then compound 2.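

In this assay capping the hydroxy oxygen with isopentyl gives a large gain (an 11-fold lower number from compound 2 to compound 3 (1.02 log units; beyond the scatter)), so the weak number of compound 2 goes with the free hydroxy and not with an oxygen at this position as such. The isopentyloxy group and the methyl group cannot be told apart here (a 1.7-fold lower number from compound 1 to compound 3 (0.23 log units; within the scatter)), so the position accepts either group with no separable change in this read-out. Nothing available explains either step. On these data alone, whether a shorter methoxy, a benzyloxy or an amine at this position would hold the number remains open.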